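The source may hold more compounds than are shown below. What is called first, only, known or untested is meant among the compounds shown, and "the series" means these compounds.

Measured compounds and their values:

Compound 1 `CC1=CC[C@H](C(C)(C)NC(=S)N/N=C/c2ccccc2O)CC1`: 10800 nM
Compound 2 `COc1cc(/C=N/NC(=S)NC(C)(C)[C@H]2CC=C(C)CC2)ccc1O`: 42300 nM
Compound 3 `CC1=CC[C@H](C(C)(C)NC(=S)N/N=C/c2ccccc2[N+](=O)[O-])CC1`: 92200 nM

In a functional assay on UACC-62 cells (Homo sapiens) for inhibition, read by sulforhodamine B assay, with a stated time of 48 h (on this read-out higher numbers stand for weaker inhibition of growth and lower numbers for stronger inhibition of growth), compound 1 gives 10800 nM and stands lowest of the three numbers, meaning it inhibits growth most strongly among them. Compound 2 gives 42300 nM and compound 3 gives 92200 nM. Within the data shown here, compound 2 differs from compound 1 in more than one place, so no single step can be drawn between them; the two values simply show compound 2 standing higher.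

The compound still to be measured is compound 4 `CC1=CC[C@H](C(C)(C)NC(=S)N/N=C/c2ccc[nH]2)CC1`. Compared with compound 1 it carries the change (1H-pyrrol-2-yl in place of 2-hydroxyphenyl on a carbon with a double bond to nitrogen).

Among the measured compounds shown here, only one measured step bears on this change, and only loosely: an 8.5-fold higher number from compound 1 to compound 3 (0.93 log units; beyond the scatter), in which the hydroxy on the aromatic ring was replaced by nitro while the ring itself stayed. Compound 4 goes further, replacing the whole 2-hydroxyphenyl with 1H-pyrrol-2-yl, which keeps a hydrogen-bond donor but has no acceptor. For the measured compounds named here, there is no measured example of a smaller ring at this position, so the expectation rests on the loss of the hydroxy alone.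

For compound 4 a modest weakening is therefore expected, a 2.0-fold higher number from compound 1 to compound 4 (0.31 log units; beyond the scatter), with the estimate 22000 nM and a range from 7000 nM to 70000 nM.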

Compound 4, concentration for total growth inhibition: 49900 nM
Beside the measured number, compound 4's estimate is 2.3-fold (0.36 log units) below it, within the range that was stated.
By their numbers in this assay, from the lowest: compound 1; then compounds 2, 4 and 3 (each within the scatter of the next, the first and the last beyond it).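

In this assay, among these compounds, exchanging the whole 2-hydroxyphenyl for 1H-pyrrol-2-yl gives a 4.6-fold higher number from compound 1 to compound 4 (0.66 log units; beyond the scatter), so the earlier result, in which only the hydroxy was replaced and the ring stayed, is no longer the only departure from compound 1 that raises the number beyond the scatter. The entering group, like the group it replaces, still has a hydrogen-bond donor, yet that shared feature was not enough to keep the value at the level of compound 1, which shows that this place on a carbon with a double bond to nitrogen is sensitive to more than the presence of a donor. No measurement offered here accounts for the size of this step.

This single step changes the ring size, the ring atoms and the hydroxy all at once, so the compounds shown cannot say which of these matters most. A plain phenyl, a 2-aminophenyl or a furan-2-yl at the same place would begin to pull these changes apart, since each alters fewer of these features at a time.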